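Thiosemicarbazone series: phenyl for methyl on the chain

The source may hold more compounds than are shown below. What is called first, only, known or untested is meant among the compounds shown, and "the series" means these compounds.

Compound 1 `CCNC(=S)N/N=C/c1ccccn1` is measured in a functional assay on SK-BR-3 cells (Homo sapiens) for inhibition, read by MTT assay, with a stated time of 24 h (on this read-out higher numbers stand for weaker inhibition of growth and lower numbers for stronger inhibition of growth), at 6300 nM. Compound 2 `C/N=C(\S)N/N=C(\C)c1cnccn1` gives 7900 nM in this assay; its number and that of compound 1 lie within the usual scatter of each other, so compound 1 stands apart from nothing yet shown. Compound 3 `S=C(NCc1ccccc1)N/N=C/c1ccccn1` awaits measurement. It differs from compound 1 by phenyl in place of methyl on a saturated chain carbon bound to an amide-type nitrogen. Going by the values given here, no measured pair carries this change. A modest step toward stronger inhibition of growth is expected, a 2.1-fold lower number from compound 1 to compound 3 (0.32 log units; beyond the scatter), though a step within the scatter would not surprise. For compound 3 the estimate in this assay is 3000 nM, with a range from 800 nM to 12000 nM.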

Compound 3, concentration for 50% growth inhibition: 4600 nM
Estimate against measurement, compound 3: 1.5-fold (0.19 log units) below; measured number inside the range.
By their numbers in this assay, from the lowest: compounds 3, 1 and 2 (each within the scatter of the next).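

Phenyl in place of methyl on a saturated chain carbon bound to an amide-type nitrogen gives the first single-place step in the series. In this assay this change gives a 1.4-fold lower number from compound 1 to compound 3 (0.14 log units; within the scatter) and so shows that this position can carry phenyl with no step beyond the scatter. Nothing at hand bears on what lies behind this result.

On these data alone, whether a longer chain, a carboxylic acid or an amine at this position would move the number beyond the scatter stays open. A single step also leaves other places on the shared core unaddressed.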